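One Ring Swapped, Little Change Expected

This account rests on a few compounds, and the source may have more. Where it says the series, first, only, none or still open, it means among the compounds named here.

In an ADME assay on microsomes from liver (Homo sapiens) for metabolic stability, read by LC-MS, using NADPH, with a stated time of 30 min, tested at 0.1 uM (on this read-out lower numbers stand for a less stable compound and higher numbers for a more stable compound), compound 3 `C[C@@]1(c2cc(NC(=O)c3ccc(C#N)cn3)ccc2F)C=C(CF)OC(N)=N1` gives 88%. Compound 1 `C[C@@]1(c2cc(NC(=O)c3coc(C(F)F)n3)ccc2F)C=C(CF)OC(N)=N1` gives 84% and compound 2 `C[C@@]1(c2cc(NC(=O)c3cnc(C(F)F)cn3)ccc2F)C=C(CF)OC(N)=N1` gives 84%, so all three sit within the scatter of one another. Compound 4 `C[C@@]1(c2cc(NC(=O)c3coc(CF)n3)ccc2F)C=C(CF)OC(N)=N1` carries 2-(fluoromethyl)-1,3-oxazol-4-yl in place of 5-cyanopyridin-2-yl on a carbonyl carbon. Three measured exchanges at this place bear on it: a number 4 percentage points higher from compound 1 to compound 3 (within the scatter), a number 4 percentage points higher from compound 2 to compound 3 (within the scatter) and no change at the digits printed from compound 1 to compound 2 (within the scatter). The nearest guide is the 2-(difluoromethyl)-1,3-oxazol-4-yl group, though no fluoromethyl group has been measured yet. The expected step is a number 6 percentage points lower from compound 3 to compound 4 (within the scatter), which means none beyond the scatter in this assay. For compound 4 the estimated value is 82%, with an expected range from 72% to 91%.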

Compound 4, percent of the compound remaining: 76%
Compound 4: the middle estimate sits 6 percentage points above what was measured, and the stated range covers the measured number.
By their numbers in this assay, from the lowest: compounds 4, 1, 2 and 3 (each within the scatter of the next, the first and the last beyond it).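

Unlike the earlier exchanges on the carbonyl carbon, one step in this assay now lies beyond the scatter: a number 12 percentage points lower from compound 3 to compound 4 (beyond the scatter). The other two stay within it, a number 8 percentage points lower from compound 2 to compound 4 (within the scatter) and a number 8 percentage points lower from compound 1 to compound 4 (within the scatter), the last being the exchange of one fluorine on the oxazole's side chain for hydrogen. Nothing available explains these differences. Going by these compounds, what stays open is how a plain methyl or a trifluoromethyl group in that same spot on the 1,3-oxazol-4-yl ring would read out in this assay.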